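The compounds below may be only part of what the source reports. "The series", "measured", "known", "first", "only" and "open" are said of these compounds alone.

Compound 3 `CCn1c(=O)/c(=C2\Sc3ccccc3N2C)s/c1=C\c1ccncc1Nc1ccccc1C` gives 990 nM in a functional assay on MCF7 cells (Homo sapiens) for inhibition (on this read-out higher numbers stand for weaker inhibition and lower numbers for stronger inhibition), the highest of the three numbers in hand. Compound 1 `CCn1c(=O)/c(=C2\Sc3ccccc3N2C)s/c1=C\c1ccncc1Nc1ccccc1F` gives 330 nM in this assay, and compound 2 `CCn1c(=O)/c(=C2\Sc3ccc(C)cc3N2C)s/c1=C\c1ccncc1Nc1ccccc1Cl` gives 650 nM. Compound 4 `CCn1c(=O)/c(=C2\Sc3ccccc3N2C)s/c1=C\c1ccncc1Nc1ccccc1Cl` is still to be measured; the change is chloro in place of methyl on an aromatic carbon. Going by the values given here, the only measured step that bears on it is a 3.0-fold higher number from compound 1 to compound 3 (0.48 log units; beyond the scatter), so the methyl group comes with the higher number. Compound 2, which carries the chloro on the same ring but also an added methyl group, sits within the scatter of compound 3. A modest fall is therefore expected, a 2.0-fold lower number from compound 3 to compound 4 (0.30 log units; within the scatter), landing between the fluoro and methyl analogues. Compound 4 is estimated at 500 nM, with a range of 250 nM to 1000 nM.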

Compound 4, half-maximal inhibitory concentration: 750 nM
Compound 4: the middle estimate sits 1.5-fold (0.18 log units) below what was measured; measured number inside the range.
By their numbers in this assay, from the lowest: compounds 1, 2, 4 and 3 (each within the scatter of the next, the first and the last beyond it).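

In this assay, chloro in place of methyl on this aromatic carbon gives a 1.3-fold lower number from compound 3 to compound 4 (0.12 log units; within the scatter), so the two groups are not separated at this position. The added methyl group of compound 2 also goes unresolved, with a 1.2-fold higher number from compound 2 to compound 4 (0.06 log units; within the scatter). Fluoro is separated from chloro, with a 2.3-fold higher number from compound 1 to compound 4 (0.36 log units; beyond the scatter), so of the groups compared here only fluoro stands apart.

Nothing at hand gives a reason for this separation. As far as these compounds go, whether a methoxy group, an amine or a carboxylic acid at this position would stay with chloro and methyl or move with fluoro remains open.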